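The source may report more compounds than this note shows. Statements on the series, on what has been measured and on what is new or still open speak of the compounds shown alone.

Measured so far, in a functional assay on HCT-116 cells (Homo sapiens), read by MTT assay, with a stated time of 72 h; on this read-out lower numbers stand for stronger inhibition and higher numbers for weaker inhibition:
Compound 1, `C#Cc1cn([C@@H]2O[C@H](CO)[C@@H](O)[C@H]2O)c2ncnc(OC)c12`, gives 5140 nM.
Compound 2, `C#Cc1cn([C@@H]2O[C@H](CO)[C@@H](O)[C@H]2O)c2ncnc(N(C)C)c12`, gives 290 nM.
Compound 3, `Cc1nc(N)c2c(-c3ccsc3)cn([C@@H]3O[C@H](CO)[C@@H](O)[C@H]3O)c2n1`, gives > 20000 nM, a limit of the assay rather than a number.

In this assay compound 1 holds the higher of the two numbers reported; the nearest is compound 2, reached by an 18-fold lower number from compound 1 to compound 2 (1.25 log units; beyond the scatter). Compound 3 sits at the limit described by the limit of > 20000 nM in this assay, at which 1 of the 3 values shown sits.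

Compound 4, `COc1ncnc2c1c(-c1cc3ccccc3o1)cn2[C@@H]1O[C@H](CO)[C@@H](O)[C@H]1O`, differs from compound 1 in one place: 1-benzofuran-2-yl in place of ethynyl on an aromatic carbon. For the measured compounds named here, the only measured step alters the methoxy, not this group, so it does not bear on the change. Going by the values given here, compound 3 shows only that a compound with an aromatic ring in this place, differing elsewhere too, reached the limit. The estimate for compound 4 is therefore 8000 nM (range 2500 nM to 25000 nM), meaning an expected 1.6-fold higher number from compound 1 to compound 4 (0.19 log units; within the scatter), within the scatter.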

Compound 4, half-maximal inhibitory concentration: 14500 nM
Estimate against measurement, compound 4: 1.8-fold (0.26 log units) below; low and high end bracket the measured number.
By their numbers in this assay, from the lowest: compound 2; then compound 1; then compound 4. At a limit, above all of these: compound 3.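

1-benzofuran-2-yl in place of ethynyl brings a 2.8-fold higher number from compound 1 to compound 4 (0.45 log units; beyond the scatter) in this assay and gives the first reading of this position, since the only earlier step altered the methoxy. Compound 4 keeps a measured number with this larger aromatic group on the same aromatic carbon. Compound 3, with an aromatic ring in this place but differing elsewhere too, stands at a limit of the assay and not at a number: the limit of > 20000 nM in this assay, at which 1 of the 4 values shown sits.

As far as these compounds go, whether an amine or a phenyl ring in this place would read nearer to ethynyl stays open. So does whether dimethylamino in place of methoxy would lower the number with 1-benzofuran-2-yl as it did with ethynyl.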